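Rat clearance notes: aryl replacement on compound 2

The compounds below may be only part of what the source reports. "The series", "measured", "known", "first", "only" and "open" are said of these compounds alone.

Measured compounds in an ADME assay on the whole organism (Rattus norvegicus) for pharmacokinetics, read by LC-MS; a lower number here means slower removal, a higher number faster removal of the compound:
- compound 1 `Cc1ccc(-c2c3c(nc(C)c2[C@H](OC(C)(C)C)C(=O)O)CCN(c2ccccc2)C3)cc1`: 24 mL/min/kg
- compound 2 `Cc1ccc(-c2c3c(nc(C)c2[C@H](OC(C)(C)C)C(=O)O)CCN(CCCc2ccccc2)C3)cc1`: 171 mL/min/kg
- compound 3 `Cc1ccc(-c2c3c(nc(C)c2C(OC(C)(C)C)C(=O)O)CCN(CCCC2CCCC2)C3)cc1`: 152 mL/min/kg

Compound 2 sits at the top of the three numbers shown, though compound 3 lies within the scatter of it, so the two cannot be told apart. For the measured compounds named here, compound 1 is the only clearly separated value, and the one traceable single-point step is a 7.1-fold higher number from compound 1 to compound 2 (0.85 log units; beyond the scatter); that change sits on the amine nitrogen in the ring, as does the difference between compound 2 and compound 3.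

Compound 4 `Cc1nc2c(c(-c3cc(F)c4c(c3C)CCCO4)c1[C@H](OC(C)(C)C)C(=O)O)CN(CCCc1ccccc1)CC2` is not yet measured. Against compound 2 its change is at the aryl position on the core: a group of 12 heavy atoms (10 carbon, 1 oxygen, 1 fluorine; one six-membered non-aromatic ring with 1 hetero atom, one six-membered aromatic ring of carbon only) in place of a group of 7 heavy atoms (7 carbon; one six-membered aromatic ring of carbon only), on an aromatic carbon. Going by the values given here, no measured step touches this position; both the step from compound 1 to compound 2 and the compound 2 / compound 3 pair concern the amine nitrogen substituent only. There is therefore no measured basis for a direction, and no step beyond the scatter is expected from the change. The expected step is a 1.1-fold lower number from compound 2 to compound 4 (0.06 log units; within the scatter), with a broad range to reflect the absence of a precedent. Compound 4 is estimated at 150 mL/min/kg in this assay, expected between 70 mL/min/kg and 320 mL/min/kg.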

Compound 4, clearance: 82 mL/min/kg
Estimate against measurement, compound 4: 1.8-fold (0.26 log units) above; the measured number falls inside the stated range.
By their numbers in this assay, from the lowest: compound 1; then compounds 4, 3 and 2 (each within the scatter of the next, the first and the last beyond it).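

The aryl position on the core, opposite the ring nitrogen, now has a measured step of its own: in this assay, the group of 12 heavy atoms in place of 4-methylphenyl gives a 2.1-fold lower number from compound 2 to compound 4 (0.32 log units; beyond the scatter). Until now, only changes at the amine nitrogen substituent could be traced to a difference in this read-out, so the aryl position is a second site that bears on the number, at least with 3-phenylpropyl on the amine nitrogen. Nothing available here bears on what underlies this step.

The entering group differs from 4-methylphenyl in several features at once, so this single pair does not assign the step to the fluorine, the oxygen-containing non-aromatic ring or the whole group, and a simpler aryl group such as 4-fluorophenyl or a pyridyl ring would be needed to separate them. As far as these compounds go, it also remains open whether the step carries over to other amine nitrogen substituents, such as the phenyl of compound 1 or a basic aminoalkyl chain.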